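Compound 2 to compound 3: fluorophenyl swap

The source may hold more compounds than are shown below. What is called first, only, known or untested is meant among the compounds shown, and "the series" means these compounds.

For the measured compounds named here, compound 2 `O=C(Nc1ccc(Oc2ccncc2-c2cccnc2)c(F)c1)c1nn(-c2cccc(F)c2)c(=O)c2ccccc12` gives 410 nM in a functional assay on HT-29 cells (Homo sapiens) for cytotoxicity, read by MTT assay, with a stated time of 72 h (a lower number here means a stronger inhibitor, a higher number a weaker inhibitor), the lower of the two numbers so far; compound 1 `COc1cc(Nc2cc(Nc3ccc(Oc4ccncc4-c4cccnc4)c(F)c3)ncn2)cc(OC)c1` gives 1130 nM there, a gap beyond the scatter. Compound 3 `O=C(Nc1ccc(Oc2ccncc2-c2cccnc2)c(F)c1)c1nn(-c2ccc(F)cc2)c(=O)c2ccccc12` keeps the rest of compound 2 and differs in one place only: 4-fluorophenyl in place of 3-fluorophenyl on an aromatic nitrogen. Going by the values given here, no step of this kind between measured compounds is available in this assay, so the step of a 1.0-fold higher number from compound 2 to compound 3 (0.01 log units; within the scatter) is an estimate, expected to reach no further than the scatter in either direction. Compound 3 is expected to give about 420 nM, between 200 nM and 900 nM.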

Compound 3, half-maximal inhibitory concentration: 990 nM
Estimate against measurement, compound 3: 2.4-fold (0.37 log units) below; the whole stated range lies below it.
By their numbers in this assay, from the lowest: compound 2; then compounds 3 and 1 (each within the scatter of the next).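

In this assay, for the compounds shown here, the substituent on the aromatic nitrogen gives the first readable step: 4-fluorophenyl in place of 3-fluorophenyl gives a 2.4-fold higher number from compound 2 to compound 3 (0.38 log units; beyond the scatter) and is a modest change. The two groups have the same atoms, so the placement of fluorine on this phenyl ring alone is enough to move the number beyond the scatter. Nothing available explains the difference.

From the compounds shown here alone, it remains open how an unsubstituted phenyl, a benzyl group or an aminophenyl would read at this nitrogen. Going by these compounds, whether the step carries over to other cores is also open.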